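The source may hold more compounds than are shown below. What is called first, only, known or untested is meant among the compounds shown, and "the series" means these compounds.

Measured compounds:
- compound 1 `Cc1cn([C@@H]2O[C@H](CO[Si](C)(C)C(C)(C)C)[C@@]3(OS(=O)(=O)C=C3NCC(N)=O)[C@H]2O[Si](C)(C)C(C)(C)C)c(=O)n(C)c1=O`: 16000 nM
- compound 2 `COC(=O)CC(=O)NC1=CS(=O)(=O)O[C@@]12[C@@H](CO[Si](C)(C)C(C)(C)C)O[C@@H](n1cc(C)c(=O)n(C)c1=O)[C@@H]2O[Si](C)(C)C(C)(C)C`: 400000 nM
- compound 3 `Cc1cn([C@@H]2O[C@H](CO[Si](C)(C)C(C)(C)C)[C@@]3(OS(=O)(=O)C=C3NCCC(=O)OCc3ccccc3)[C@H]2O[Si](C)(C)C(C)(C)C)c(=O)n(C)c1=O`: >= 400000 nM

In a functional assay on HEL cells (Homo sapiens) for cytotoxicity, read by microscopy (on this read-out lower numbers stand for higher toxicity in this test and higher numbers for lower toxicity in this test), compound 3 stands at the upper edge of the series: its reading is a limit of the test, not a number, (the limit of >= 400000 nM in this assay, at which 1 of the 3 values shown sits). Compound 1 gives 16000 nM, and compound 2 gives 400000 nM. The two steps into compound 3 are an at least 25-fold higher number from compound 1 to compound 3 (1.39 log units; beyond the scatter) and a number no lower from compound 2 to compound 3 (the limit leaves the size open); the step of a 25-fold higher number from compound 1 to compound 2 (1.40 log units; beyond the scatter) shows that a small carbamoylmethyl group on the amine nitrogen goes with the lowest number in the set.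

Compound 4 `CCNC(=O)NC1=CS(=O)(=O)O[C@@]12[C@@H](CO[Si](C)(C)C(C)(C)C)O[C@@H](n1cc(C)c(=O)n(C)c1=O)[C@@H]2O[Si](C)(C)C(C)(C)C` differs from compound 3 by ethylcarbamoyl in place of 2-(benzyloxycarbonyl)ethyl on an amine nitrogen. Within the data shown here, no measured step covers this exact exchange. The group that enters is short and carries one hydrogen-bond donor, closer in size to the carbamoylmethyl of compound 1 than to the groups of compound 2 or compound 3. The number for compound 4 is therefore expected to fall below the limit of compound 3, by a step of about an at least 4.0-fold lower number from compound 3 to compound 4 (0.60 log units; beyond the scatter), with compound 1 as the low bound. Compound 4 is estimated at 100000 nM, between 20000 nM and 400000 nM.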

Compound 4, minimum cytotoxic concentration: >= 3200 nM
Compound 4 was reported as a limit (the forecaster's own chance of this, stated with the estimate: 40%); the middle value lies beyond the limit too.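

The reading for compound 4, >= 3200 nM, is a limit and not a number. Among these compounds, no step to compound 4 from compound 1, compound 2 or compound 3 can be read. Still open, as far as these compounds go, is whether ethylcarbamoyl on the amine nitrogen goes with a number nearer that of compound 1 or that of compound 2.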